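A Small Rearrangement on a Weak Alcohol Dehydrogenase Inhibitor

The source may report more compounds than this note shows. Statements on the series, on what has been measured and on what is new or still open speak of the compounds shown alone.

Compound 1 `COCC(N)=O` is the starting point. Among the compounds with values here, in an assay for inhibition of alcohol dehydrogenase (Equus caballus) (a higher number here means a weaker inhibitor, a lower number a stronger inhibitor), compound 1 gives 600000 nM, the highest of the three numbers measured so far. Compound 3 `CC[S+](C)[O-]` gives 500000 nM in this assay, which lies within the scatter of compound 1. Compound 2 `CCCCCCCCCCCCCC[S+](C)[O-]` gives 10000 nM in this assay, a number far lower than that of compound 1. Compound 4 `NC(=O)CCO` has the same atoms as compound 1, joined differently: hydroxymethyl in place of methoxy on a saturated chain carbon bound to a carbonyl carbon. Within the data shown here, no measured pair shows what such a rearrangement does in this assay, so no step beyond the scatter is expected in either direction. Compound 4 is therefore estimated at 500000 nM, within a range of 150000 nM to 2000000 nM. The step this estimate means, a 1.2-fold lower number from compound 1 to compound 4 (0.08 log units; within the scatter), is expected to stay within the scatter.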

Compound 4, inhibition constant: 8500000 nM
Estimate against measurement, compound 4: 17-fold (1.23 log units) below; measured number above the stated range.
By their numbers in this assay, from the lowest: compound 2; then compounds 3 and 1 (each within the scatter of the next); then compound 4.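

Replacing methoxy with hydroxymethyl on a saturated chain carbon bound to a carbonyl carbon is far from a neutral swap in this assay: it gives a 14-fold higher number from compound 1 to compound 4 (1.15 log units; beyond the scatter), a clearly weaker inhibitor. The number here therefore depends on how the atoms are joined, even when the atoms themselves stay the same. The entering group also carries a hydrogen-bond donor that methoxy lacks, but no measurement available explains the step. As far as these compounds go, whether that donor or the new connection of atoms matters more stays open. So does what an amine or a longer chain would do on this carbon.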